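The source may hold more compounds than are shown below. What is called first, only, known or untested is meant among the compounds shown, and "the series" means these compounds.

In an assay on CHO cells for antagonist activity at lysophosphatidic acid receptor 5 (Rattus norvegicus), read by cAMP accumulation, with a stated time of 30 min (a lower number here means a stronger inhibitor, a higher number a weaker inhibitor), compound 2 `COc1cc2c(C(=O)N3CCCCCC3)cn(-c3ccc(C)c(C)c3)c(=O)c2cc1OC` gives 720 nM, which stands second highest of the three numbers recorded, close to compound 3 `CCOc1ccc(-n2cc(C(=O)N3CCC(F)CC3)c3cc(OC)c(OC)cc3c2=O)cc1` at 750 nM and well apart from compound 1 `CCN1CCc2ccc(-n3cc(C(=O)N4CCC(F)CC4)c4cc(OC)c(OC)cc4c3=O)cc21` at 120 nM. Compound 4 `CCN1CCc2ccc(-n3cc(C(=O)N4CCCCCC4)c4cc(OC)c(OC)cc4c3=O)cc21` differs from compound 2 in one place: 1-ethyl-2,3-dihydro-1H-indol-6-yl in place of 3,4-dimethylphenyl on an aromatic nitrogen. For the measured compounds named here, the only measured step that bears on this exchange runs the opposite way, a 6.3-fold higher number from compound 1 to compound 3 (0.80 log units; beyond the scatter), where compound 1 carries the 1-ethyl-2,3-dihydro-1H-indol-6-yl group and compound 3 the 4-ethoxyphenyl group, both with the same amide. Read in reverse, that step points toward a lower number in this assay for compound 4. Compound 4 is therefore expected to show a 5.5-fold lower number from compound 2 to compound 4 (0.74 log units; beyond the scatter). The estimated value of compound 4 in this assay is 130 nM, within a range of 50 nM to 350 nM.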

Compound 4, half-maximal inhibitory concentration: 110 nM
Compound 4: the middle estimate sits 1.2-fold (0.07 log units) above what was measured; the measured number falls inside the stated range.
By their numbers in this assay, from the lowest: compounds 4 and 1 (each within the scatter of the next); then compounds 2 and 3 (each within the scatter of the next).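

In this assay the 1-ethyl-2,3-dihydro-1H-indol-6-yl group on the aromatic nitrogen again gives a lower number, now with the azepan-1-yl amide and against 3,4-dimethylphenyl (a 6.5-fold lower number from compound 2 to compound 4 (0.82 log units; beyond the scatter)). With that group in place, azepan-1-yl in place of 4-fluoropiperidin-1-yl on the carbonyl carbon leaves the number within the scatter (a 1.1-fold lower number from compound 1 to compound 4 (0.04 log units; within the scatter)). No measurement shown explains either result. Still open, as far as these compounds go, is whether the ethyl on the ring nitrogen matters, as a methyl or a hydrogen there would show. Also open, from the compounds shown here alone, is how a morpholine amide would fare at the carbonyl carbon.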